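A Pyrrolyl Chain Tested on a Phenyl-Bearing Analog

The source may report more compounds than this note shows. Statements on the series, on what has been measured and on what is new or still open speak of the compounds shown alone.

Measured compounds, in a functional assay on A549 cells (Homo sapiens) for antiproliferative activity, read by MTT assay, with a stated time of 48 h; on this read-out higher numbers stand for weaker inhibition and lower numbers for stronger inhibition:
Compound 1 `Cn1cc(C2=C(c3nn(CCCn4cccc4)c4ncccc34)C(=O)NC2=O)c2ccccc21` gives > 100000 nM, which is a limit of the assay.
Compound 2 `CN(C)CCCn1nc(C2=C(c3cn(C)c4ccccc34)C(=O)N(c3ccccc3)C2=O)c2cccnc21` gives 13000 nM.
Compound 3 `CN(C)CCCn1nc(C2=C(c3cn(C)c4ccccc34)C(=O)NC2=O)c2cccnc21` gives > 100000 nM, which is a limit of the assay.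

Compound 4 `Cn1cc(C2=C(c3nn(CCCn4cccc4)c4ncccc34)C(=O)N(c3ccccc3)C2=O)c2ccccc21` has not yet been tested. Compound 2 and compound 3 share a core and differ by phenyl in place of hydrogen on an amide-type nitrogen in a ring; the step of an at least 7.6-fold higher number from compound 2 to compound 3 (0.88 log units; beyond the scatter) shows that, of these three, only the phenyl-bearing compound 2 gives a readable number. Compound 4 is compound 2 with the change (1H-pyrrol-1-yl in place of dimethylamino on a saturated chain carbon, three bonds along the chain from an aromatic nitrogen). The same change was made once already, from compound 3 to compound 1, as 1H-pyrrol-1-yl in place of dimethylamino on a saturated chain carbon, three bonds along the chain from an aromatic nitrogen; both of those compounds sit at the limit (the limit of > 100000 nM in this assay, at which 2 of the 3 values shown sit), so the step that the two limits leave unreadable from compound 3 to compound 1 cannot be sized. With the pyrrolyl change otherwise unread, the expectation rests only on compound 2 and its value 13000 nM. Compound 4 is thus expected to stay near that number, with a step of a 1.2-fold higher number from compound 2 to compound 4 (0.06 log units; within the scatter). The estimate for compound 4 is 15000 nM, expected between 4000 nM and 60000 nM.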

Compound 4, half-maximal inhibitory concentration: > 100000 nM
Compound 4: only a limit was reported (the forecaster's own chance of this, stated with the estimate: 25%); middle value at least 6.6-fold (0.82 log units) from the limit.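

In this assay, replacing dimethylamino with 1H-pyrrol-1-yl at the end of the chain on the phenyl-bearing core gives an at least 7.6-fold higher number from compound 2 to compound 4 (0.88 log units; beyond the scatter). Compound 4 gives > 100000 nM, which is a limit of the assay and not a number, so the step has a known minimum but no known full size. The change therefore weakens the result on this core, but it does not show whether the same happens on the core with the amide hydrogen, and neither that step nor the phenyl step from compound 1 to compound 4 can be read because both ends of each are limits: the limit of > 100000 nM in this assay, at which 3 of the 4 values shown sit.

As far as these compounds go, it remains open whether the loss follows from removing dimethylamino or from introducing the pyrrole ring, a question that a 3-(pyrrolidin-1-yl)propyl or 3-(morpholin-4-yl)propyl chain on the phenyl-bearing core could help to answer. From the compounds shown here alone, it also remains open whether a group such as benzyl on the ring nitrogen would give a readable number.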